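This account rests on a few compounds, and the source may have more. Where it says the series, first, only, none or still open, it means among the compounds named here.

For the measured compounds named here, compound 3 `O=C(Nc1ccccc1)c1nc(=O)[nH]c2ccccc12` gives 50 nM in an assay on CHO cells for displacement of a labelled ligand from adenosine receptor A3 (Homo sapiens) (a lower number here means a stronger inhibitor, a higher number a weaker inhibitor), the lowest of the three numbers measured so far. Compound 1 `Cc1ccc(NC(=O)c2nc(N)nc3ccccc23)cc1` gives 98.3 nM in this assay, a gap to compound 3 that lies within the scatter, whereas compound 2 `Nc1nc(C(=O)Nc2ccc(Br)cc2)c2ccccc2n1` gives 550 nM, a gap beyond the scatter.

Compound 4 `O=C(Nc1ccc(Br)cc1)c1nc(=O)[nH]c2ccccc12` is compound 3 with bromo in place of hydrogen on an aromatic carbon. Going by the values given here, only one measured step bears on this change: a 5.6-fold higher number from compound 1 to compound 2 (0.75 log units; beyond the scatter), in which bromo replaced methyl on the core of compound 1. That step is not the same change. There the bromo displaced a methyl rather than a hydrogen, and it sits on a different core than that of compound 3. Among the compounds with values here, no compound with hydrogen at that position on the core of compound 1 has been measured, so a direct hydrogen-to-bromo comparison is absent.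

Taking the weakening seen from compound 1 to compound 2 as the nearest guide, and allowing for the different starting group and core, a modest rise in the number is expected for compound 4, namely a 3.6-fold higher number from compound 3 to compound 4 (0.56 log units; beyond the scatter). Compound 4 is therefore estimated at 180 nM in this assay, with a range from 55 nM to 600 nM.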

Compound 4, inhibition constant: 27.2 nM
For compound 4 the middle estimate is 6.6-fold (0.82 log units) above the measured one, and the stated range ends above it.
By their numbers in this assay, from the lowest: compounds 4, 3 and 1 (each within the scatter of the next, the first and the last beyond it); then compound 2.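

On the core of compound 3, going from phenyl to 4-bromophenyl gives a 1.8-fold lower number from compound 3 to compound 4 (0.26 log units; within the scatter) in this assay, so at this place, para to a large group, bromo in place of hydrogen leaves the number within the usual scatter. For the compounds shown here, until now the only step involving bromo was a 5.6-fold higher number from compound 1 to compound 2 (0.75 log units; beyond the scatter), and compound 4 shows that the rise in that step does not come with bromo at this place on every core; that step started from methyl rather than hydrogen on a different core, so it cannot show whether the core or the group that left accounts for the difference between the two results. Nothing available explains why bromo is tolerated here on the core of compound 3.

The compounds shown leave open how a methyl, an amine or a carboxylic acid at this same place on the core of compound 3 would compare with hydrogen and bromo. They also leave open what hydrogen at this place would give on the core of compound 1, which would separate the effect of the core from that of the group replaced.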